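This account rests on a few compounds, and the source may have more. Where it says the series, first, only, none or still open, it means among the compounds named here.

Compound 1 `Cc1ccc2[nH]c(=O)c(/C=N/c3ccc(O)cc3)cc2c1` and compound 2 `O=c1[nH]c2ccccc2cc1/C=N/c1ccc(O)cc1` share a core and differ by hydrogen in place of methyl on an aromatic carbon. In a functional assay, read by spectrophotometry, with a stated time of 3 min (a lower number here means a stronger inhibitor, a higher number a weaker inhibitor), compound 1 gives 5240 nM, while compound 2 gives 7150 nM, and the step between them is a 1.4-fold higher number from compound 1 to compound 2 (0.13 log units; within the scatter). Compound 3 `Cc1ccc2[nH]c(=O)c(/C=N/Nc3ccc([N+](=O)[O-])cc3)cc2c1` belongs to a second core; the difference between the two cores is not broken down here. In this assay compound 3 gives 8250 nM, which lies within the scatter of both compound 1 and compound 2. Compound 4 `O=c1[nH]c2ccccc2cc1/C=N/Nc1ccc([N+](=O)[O-])cc1` arises from compound 3 through (hydrogen in place of methyl on an aromatic carbon), the same change, at a place described in identical words. Resting on a 1.4-fold higher number from compound 1 to compound 2 (0.13 log units; within the scatter), which stayed within the scatter, a similar step is expected for compound 4 in this assay: a 1.3-fold higher number from compound 3 to compound 4 (0.10 log units; within the scatter). Compound 4 is thus estimated at 10500 nM, between 5500 nM and 20000 nM.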

Compound 4, half-maximal inhibitory concentration: 11400 nM
Estimate against measurement, compound 4: 1.1-fold (0.04 log units) below; the measured number falls inside the stated range.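

In this assay, hydrogen in place of methyl on an aromatic carbon gives a 1.4-fold higher number from compound 3 to compound 4 (0.14 log units; within the scatter). Set beside the earlier step, the change carries over from one core to the other at much the same size: the same change on two cores in this assay, a 1.4-fold higher number (0.13 log units; within the scatter) from compound 1 to compound 2 and a 1.4-fold higher number (0.14 log units; within the scatter) from compound 3 to compound 4, 1.0-fold (0.01 log units) apart, within the scatter of two such steps. Going by these compounds alone, each step lies within the scatter, so the two pairs show only that this change leaves no readable difference on these two cores; they do not show a real shift in either direction, nor that the same would hold on a third core.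

The compounds shown leave open whether a larger group at this place, such as a methoxy group, a chlorine atom or an amine, would give a step beyond the scatter. They also leave open whether the change would carry over as it does here with a carboxylic acid on the far aromatic ring.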